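The source may hold more compounds than are shown below. What is called first, only, known or untested is meant among the compounds shown, and "the series" means these compounds.

In an ADME assay on BaF3 cells (Mus musculus) for antiproliferative activity (a lower number here means a stronger inhibitor of growth, a higher number a weaker inhibitor of growth), compound 1 (`Cc1ccc(NC(=O)c2ccc(C)c(C(F)(F)F)c2)cc1OC1CCN(C(=O)c2cccnc2)CC1`) gives 5470 nM as its measured value. For the measured compounds named here, only one other compound has a number so far: compound 2 (`Cc1ccc(NC(=O)c2ccc(C)c(C(F)(F)F)c2)cc1OC1CCN(C(=O)c2ccno2)CC1`) gives 8940 nM and the two lie within the usual scatter of each other, so compound 1 cannot be ranked against it. Compound 3 (`Cc1ccc(NC(=O)Nc2ccc(Cl)c(C(F)(F)F)c2)cc1OC1CCN(C(=O)c2cccnc2)CC1`) has (4-chloro-3-(trifluoromethyl)phenyl)amino in place of 4-methyl-3-(trifluoromethyl)phenyl on a carbonyl carbon while the pyridin-3-yl group of compound 1 stays as it is. Going by the values given here, the only measured step (a 1.6-fold higher number from compound 1 to compound 2 (0.21 log units; within the scatter)) swaps pyridin-3-yl for 1,2-oxazol-5-yl, which is a different part of the molecule, so it offers no direct guide to this change. Among the compounds with values here, no measured compound carries the entering group, and the data therefore fix neither the size nor the direction of the step. A moderate step towards stronger growth inhibition is expected (a 2.2-fold lower number from compound 1 to compound 3 (0.34 log units; beyond the scatter)) but this is a judgement with wide uncertainty. For compound 3 the estimated value is 2500 nM with an expected range from 500 nM to 10000 nM around it.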

Compound 3, concentration for 50% growth inhibition: 3300 nM
Estimate against measurement, compound 3: 1.3-fold (0.12 log units) below, and the stated range covers the measured number.
By their numbers in this assay, from the lowest: compounds 3, 1 and 2 (each within the scatter of the next, the first and the last beyond it).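

Compounds 1 and 2 differ only at the pyridin-3-yl end, so they say nothing about the other side of the molecule, where a carbonyl carbon carries 4-methyl-3-(trifluoromethyl)phenyl. In this assay, placing (4-chloro-3-(trifluoromethyl)phenyl)amino on that carbonyl carbon gives a 1.7-fold lower number from compound 1 to compound 3 (0.22 log units; within the scatter) and so shows that this place can take a group bringing a nitrogen, a chlorine and a hydrogen-bond donor with no difference that stands clear of the scatter. Nothing further is measured that could explain this result.

The nitrogen and the chlorine enter together, so this single step cannot show what each does alone, and they might even pull in opposite directions with a small net result. For the compounds shown here, that would take compounds in which only one of them changes, for example the amino link with the methyl group kept, while a methoxy group in place of the chlorine, or an oxygen link in place of the amino nitrogen, would show how far this place tolerates other groups.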